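The source may hold more compounds than are shown below. What is called first, only, known or untested is meant among the compounds shown, and "the series" means these compounds.

Within the data shown here, compound 3 `Cn1ccnc1CN1CCC[C@H](OCc2cc(Cl)cc(Cl)c2)[C@@H]1c1ccccc1` gives 165000 nM in an assay on isolated protein for activation of cGMP-dependent protein kinase 1 (Homo sapiens), read by ADP-Glo, with stated times of 120 min and 40 min (a higher number here means that more compound is needed for the effect, a lower number that less compound is needed), the highest of the three numbers measured so far. Compound 2 `O=C(O)c1cncc(CN2CCC[C@H](OCc3cc(Cl)cc(Cl)c3)[C@@H]2c2ccccc2)c1` gives 117000 nM, and the gap between them is a 1.4-fold higher number from compound 2 to compound 3 (0.15 log units; within the scatter). Compound 1 `O=C(O)c1ccc(CN2CCC[C@H](OCc3cc(Cl)cc(Cl)c3)[C@@H]2c2ccccc2)s1` gives 76000 nM, and here the gap is a 2.2-fold higher number from compound 1 to compound 3 (0.34 log units; beyond the scatter), so compound 3 stands clearly apart from compound 1 only.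

Compound 4 `Clc1cc(Cl)cc(CO[C@H]2CCCN(Cc3ccc(-c4nn[nH]n4)cc3)[C@H]2c2ccccc2)c1` has not yet been measured. It differs from compound 3 in one place: 4-(2H-tetrazol-5-yl)phenyl in place of 1-methyl-1H-imidazol-2-yl on a saturated chain carbon bound to an amine nitrogen in a ring. The measured steps that bear on this change are the two in which the 1-methyl-1H-imidazol-2-yl group took the place of an aromatic ring carrying a carboxylic acid: a 2.2-fold higher number from compound 1 to compound 3 (0.34 log units; beyond the scatter) and a 1.4-fold higher number from compound 2 to compound 3 (0.15 log units; within the scatter). Both ran toward a higher number, one beyond the scatter and one within it. The change to compound 4 runs the other way, away from the imidazole toward a larger aromatic group, and a downward step is expected because a 2.2-fold higher number from compound 1 to compound 3 (0.34 log units; beyond the scatter) rose when the carboxylic acid ring was lost. The expected step is a 2.1-fold lower number from compound 3 to compound 4 (0.31 log units; beyond the scatter), modest and close to the edge of the scatter. Compound 4 is thus estimated to give 80000 nM in this assay, with a range from 30000 nM to 200000 nM.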

Compound 4, half-maximal effective concentration: 74000 nM
For compound 4 the middle estimate is 1.1-fold (0.03 log units) above the measured one; the measured number falls inside the stated range.
By their numbers in this assay, from the lowest: compounds 4, 1, 2 and 3 (each within the scatter of the next, the first and the last beyond it).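

In this assay, the group on a saturated chain carbon bound to an amine nitrogen in a ring can be exchanged for 4-(2H-tetrazol-5-yl)phenyl, which brings a six-membered carbon ring and a five-membered ring with 4 hetero atoms, with a 2.2-fold lower number from compound 3 to compound 4 (0.35 log units; beyond the scatter); this is a modest step, but the number moves downward, so the position tolerates this bigger two-ring group. The earlier compounds shown here held only carboxylic acids on a single ring and the imidazole, and the new group, which has no carboxylic acid, cannot be told apart from either carboxylic acid compound, with a 1.6-fold lower number from compound 2 to compound 4 (0.20 log units; within the scatter) and a 1.0-fold lower number from compound 1 to compound 4 (0.01 log units; within the scatter). Nothing measured here explains these numbers.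

The compounds shown leave open whether the tetrazole or the phenyl ring it sits on carries the step, and a plain phenyl or a phenyl bearing a carboxylic acid at the same place would separate the two. From the compounds shown here alone, it is also open whether a longer chain linking the ring nitrogen to the tetrazole, or a simple amine in its place, would move the number further than the scatter.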